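From 4-chlorophenyl to 2-bromophenyl in a growth inhibition series

This account rests on a few compounds, and the source may have more. Where it says the series, first, only, none or still open, it means among the compounds named here.

Compound 1 `Cc1ccc(CS(=O)(=O)/C(=C/c2c[nH]c3ccc(Br)cc23)C(=O)c2ccc(Cl)cc2)cc1`: 10000 nM
Compound 2 `Cc1ccc(CS(=O)(=O)/C(=C/c2ccc(Cl)cc2)C(=O)c2ccc(Cl)cc2)cc1`: 25000 nM

In a functional assay on DU-145 cells (Homo sapiens) for inhibition, read by trypan blue exclusion, with a stated time of 96 h (a higher number here means a weaker inhibitor of growth, a lower number a stronger inhibitor of growth), compound 2 gives 25000 nM, the higher of the two numbers. Compound 3 `Cc1ccc(CS(=O)(=O)/C(=C/c2ccccc2Br)C(=O)c2ccc(Cl)cc2)cc1` differs from it at one place (2-bromophenyl in place of 4-chlorophenyl on a double-bonded chain carbon bound to a double-bonded chain carbon). For the measured compounds named here, the only measured step at that place is a 2.5-fold higher number from compound 1 to compound 2 (0.40 log units; beyond the scatter), a modest change that replaced 5-bromo-1H-indol-3-yl with 4-chlorophenyl. Going by the values given here, no measured step yet compares two substituted phenyl groups, so no clear direction can be drawn, and a change smaller than that modest step is expected. The estimated step is a 1.3-fold lower number from compound 2 to compound 3 (0.10 log units; within the scatter), which is not expected to exceed the scatter. Compound 3 is expected at 20000 nM, with an estimated range of 8000 nM to 50000 nM.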

Compound 3, concentration for 50% growth inhibition: 25000 nM
Beside the measured number, compound 3's estimate is 1.3-fold (0.10 log units) below it, and the stated range covers the measured number.
By their numbers in this assay, from the lowest: compound 1; then compounds 2 and 3 (each within the scatter of the next).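

At this place on the double-bonded chain carbon, 2-bromophenyl and 4-chlorophenyl cannot be told apart in this assay (no change at the digits printed from compound 2 to compound 3 (within the scatter)). The 5-bromo-1H-indol-3-yl of compound 1 now keeps its edge over two different substituted phenyl groups, not one (a 2.5-fold higher number from compound 1 to compound 3 (0.40 log units; beyond the scatter)). No evidence is available to explain either result.

From the compounds shown here alone, this single change swaps the halogen and its ring position together, so their separate contributions remain unknown. Also open, going by these compounds, is how a phenyl group carrying an amine or a carboxylic acid would behave at this place.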